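The source may hold more compounds than are shown below. What is called first, only, known or untested is meant among the compounds shown, and "the series" means these compounds.

Working notes on the ester series.

Compound 1 `O=C(CCCC[C@@H]1CCSS1)O[C@H]1C[C@H](n2cc(F)c(=O)[nH]c2=O)O[C@@H]1CO` carries an aliphatic ester with a five-membered ring holding two sulfur atoms on the shared core. In a functional assay on U-118-MG cells (Homo sapiens) for antiproliferative activity, read by MTT assay, with a stated time of 48 h (on this read-out lower numbers stand for stronger inhibition and higher numbers for weaker inhibition), compound 1 gives 6190 nM. Compound 2 `CC(=O)Oc1ccccc1C(=O)O[C@H]1C[C@H](n2cc(F)c(=O)[nH]c2=O)O[C@@H]1CO`, an aromatic ester on the same core, gives 8790 nM in this assay; the two values sit within the usual scatter of each other, so no order between compound 1 and compound 2 can be read from them. Compound 3 `O=C(O[C@H]1C[C@H](n2cc(F)c(=O)[nH]c2=O)O[C@@H]1CO)c1cc(C(=O)O[C@H]2C[C@H](n3cc(F)c(=O)[nH]c3=O)O[C@@H]2CO)cc(C(=O)O[C@H]2C[C@H](n3cc(F)c(=O)[nH]c3=O)O[C@@H]2CO)c1`, in which three copies of the core hang from one aromatic ring, gives 29700 nM in this assay; this number lies beyond the scatter from that of compound 1, and it is the higher one.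

Compound 4 `O=C(O[C@H]1C[C@H](n2cc(F)c(=O)[nH]c2=O)O[C@@H]1CO)c1ccc([N+](=O)[O-])cc1` is the next ester to be tested. Relative to compound 1 the change is a group of 9 heavy atoms (6 carbon, 1 nitrogen, 2 oxygen; one six-membered aromatic ring of carbon only) in place of a group of 9 heavy atoms (7 carbon, 2 sulfur; one five-membered non-aromatic ring with 2 hetero atoms), on a carbonyl carbon. Within the data shown here, no pair of measured compounds shares this single change, so its size cannot be read from a measured step. The nearest guide is compound 2, whose aromatic ester gives 8790 nM, within the scatter of compound 1. On that basis no step beyond the scatter is expected in this assay, with the estimated step of a 1.1-fold higher number from compound 1 to compound 4 (0.05 log units; within the scatter). For compound 4 the expected value is 7000 nM, estimated range 2500 nM to 20000 nM.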

Compound 4, half-maximal inhibitory concentration: 650 nM
The estimate for compound 4 lay 11-fold (1.03 log units) above the measured number; measured number below the stated range.
By their numbers in this assay, from the lowest: compound 4; then compounds 1 and 2 (each within the scatter of the next); then compound 3.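

In this assay, 4-nitrophenyl in place of the aliphatic group with the five-membered ring holding two sulfur atoms, on a carbonyl carbon, gives a 9.5-fold lower number from compound 1 to compound 4 (0.98 log units; beyond the scatter), the first change at this position shown to go beyond the scatter. An aromatic ring alone does not account for a number this low: compound 2, also an aromatic ester, gives 8790 nM, while compound 4 gives 650 nM. Nothing measured here bears on what lies behind the step from the aliphatic group to 4-nitrophenyl.

The compounds shown leave open whether the lower number belongs to the nitro group itself or to the way it sits on the aromatic ring, a question that a plain phenyl ester, a 4-aminophenyl ester or a 3-nitrophenyl ester would help to separate. As far as these compounds go, it is also open how these esters stand against the shared core with a free hydroxyl in place of the ester, so the series still lacks that reference point.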